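The source may hold more compounds than are shown below. What is called first, only, known or untested is meant among the compounds shown, and "the series" means these compounds.

Measured so far:
- compound 1 `COc1ccccc1-c1ncnn1-c1cc(OC)c(OC)c(OC)c1` — > 10000 nM in a functional assay on Jurkat cells (Homo sapiens) for antiproliferative activity, read by MTT assay, with a stated time of 72 h; a lower number here means a stronger inhibitor, a higher number a weaker inhibitor
- compound 2 `COc1cc(-c2ncnn2-c2ccc(N)cc2)cc(OC)c1OC` — > 10000 nM

Compound 1 is known only as a limit of this assay, given as > 10000 nM. Compound 2 likewise shows only a limit, > 10000 nM. Both values therefore sit at the limit of > 10000 nM in this assay, at which 2 of the 2 values shown sit, and nothing in the series yet places any member on a numbered scale. For the measured compounds named here, no step between measured compounds is available, so the effect of rearranging the methoxyphenyl group is untested.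

Compound 3 `COc1cccc(-c2ncnn2-c2cc(OC)c(OC)c(OC)c2)c1` is the next candidate. It differs from compound 1 by 3-methoxyphenyl in place of 2-methoxyphenyl on an aromatic carbon, the exchange taking place on an aromatic carbon of a five-membered aromatic ring with 3 nitrogen, between two ring nitrogen atoms, next to the ring atom that bears a large group.

With both measured compounds at the limit, the step from compound 1 to compound 3 is expected to be small or none beyond the scatter, most likely leaving compound 3 at the same limit: a step that the limit leaves unreadable from compound 1 to compound 3 is the expected step. Compound 3 is estimated at 15000 nM, within 3000 nM to 60000 nM.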

Compound 3, half-maximal inhibitory concentration: > 10000 nM
Compound 3: only a limit was reported; the forecaster's own chance of this, stated with the estimate: 70%; the middle value lies beyond the limit too.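

Compound 3 gives only a limit in this assay, > 10000 nM, so no step from compound 1 to compound 3 can be read: the limit of > 10000 nM in this assay, at which 3 of the 3 values shown sit.

The compounds shown leave open whether any member of the series reaches a numbered value in this assay, and what 3-methoxyphenyl in place of 2-methoxyphenyl does to activity there.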